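The source may report more compounds than this note shows. Statements on the series, on what has been measured and on what is new or still open speak of the compounds shown alone.

Measured so far:
- compound 2 `COc1cc2c(Oc3ccc(NC(=O)c4nn(-c5ccc(F)c(F)c5)c(=O)cc4C)cc3F)ccnc2cc1OCCCN1CCCC1` gives 80 nM
- compound 1 `COc1ccc(-n2nc(C(=O)Nc3ccc(Oc4ccnc5cc(OCCCN6CCN(C)CC6)c(OC)cc45)c(F)c3)c(C)cc2=O)cc1` gives 1230 nM

Both numbers come from a functional assay on MKN-45 cells (Homo sapiens) for inhibition, read by MTT assay, with a stated time of 72 h; on this read-out higher numbers stand for weaker inhibition and lower numbers for stronger inhibition. Of the two, compound 2 has the lower number, and the gap to compound 1 is wider than the usual scatter of repeated measurements, so compound 2 stands as the more potent of the pair. The two structures differ in several places at once, so nothing can be said about which change carries that gap.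

Compound 3 `COc1cc2c(Oc3ccc(NC(=O)c4nn(-c5ccc(F)c(F)c5)c(=O)cc4C)cc3F)ccnc2cc1OCCCN1CCN(C)CC1` differs from compound 2 in one place only: 4-methylpiperazin-1-yl in place of pyrrolidin-1-yl on a saturated chain carbon, three bonds along the chain from an oxygen on an aromatic ring. This tail sits on the side chain, away from the amide and the fluorinated aryl groups that the two compounds share. Within the data shown here, no measured pair isolates this exchange, so the expectation rests on the single starting value of compound 2. The exchanged groups are both small saturated rings at the chain end, and the step from compound 2 to compound 3 is expected to be small, a 1.5-fold higher number from compound 2 to compound 3 (0.18 log units; within the scatter), with no clear direction beyond the scatter. Compound 3 is therefore estimated at 120 nM, within a range of 40 nM to 400 nM.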

Compound 3, half-maximal inhibitory concentration: 120 nM
The estimate for compound 3 equals the measured number at the digits printed; measured number inside the range.
By their numbers in this assay, from the lowest: compounds 2 and 3 (each within the scatter of the next); then compound 1.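

In this assay, 4-methylpiperazin-1-yl in place of pyrrolidin-1-yl at the end of the chain gives a 1.5-fold higher number from compound 2 to compound 3 (0.18 log units; within the scatter), so the two rings cannot be told apart at this place, even though the entering ring is larger and holds a second nitrogen. Compound 3 also carries the same tail as compound 1 and differs from it in one place only: 3,4-difluorophenyl in place of 4-methoxyphenyl on an aromatic nitrogen gives a 10-fold lower number from compound 1 to compound 3 (1.01 log units; beyond the scatter), which puts a large change at that nitrogen and not in the tail. Nothing available explains why either step has the size it has.

On these data alone, whether that large step follows from the two fluorines arriving or from the methoxy group leaving remains open, and a plain phenyl or a 4-fluorophenyl on the aromatic nitrogen would help separate the two. The chain end is also covered by only these two rings, so the outcome with a morpholin-4-yl ring, an open-chain dimethylamino group or a shorter chain cannot be told from the compounds shown.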